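This account rests on a few compounds, and the source may have more. Where it says the series, first, only, none or still open, it means among the compounds named here.

Values in a functional assay on HeLa cells (Homo sapiens) for inhibition, read by CCK-8 assay, with a stated time of 48 h; a lower number here means a stronger inhibitor, a higher number a weaker inhibitor:

- compound 1 `COc1cc(-c2ccnc3cc(-c4cn(CO)c5ccccc45)nn23)cc(OC)c1OC`: 103 nM
- compound 2 `COc1cc(-c2cc3nccc(-c4c[nH]c5ccccc45)n3n2)cc(OC)c1OC`: > 10000 nM (a limit of the assay, not a number)
- compound 3 `COc1cc(-c2ccnc3cc(-c4ccc(Cl)cc4)nn23)cc(OC)c1OC`: 1490 nM

Of the two numerical values, compound 3 holds the higher one at 1490 nM. Its nearest neighbour, compound 1, lies lower at 103 nM, a gap beyond the scatter.

Compound 4 `COc1cc(-c2ccnc3cc(-c4ccccc4)nn23)cc(OC)c1OC` differs from compound 3 in one place: 4-chlorophenyl becomes phenyl, with hydrogen in place of chloro on an aromatic carbon, para to a large group (hydrogen in place of chloro on an aromatic carbon).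

For the measured compounds named here, no measured pair isolates this change, so compound 3 at 1490 nM is the only anchor. In this assay a small move towards a higher number is expected, with no step beyond the scatter. The expected step is a 1.7-fold higher number from compound 3 to compound 4 (0.22 log units; within the scatter). The estimate for compound 4 is 2500 nM, with an expected range of 700 nM to 9000 nM.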

Compound 4, half-maximal inhibitory concentration: 458 nM
For compound 4 the middle estimate is 5.5-fold (0.74 log units) above the measured one; the whole stated range lies above it.
By their numbers in this assay, from the lowest: compound 1; then compound 4; then compound 3. At a limit, above all of these: compound 2.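

In this assay, hydrogen in place of chloro on the aromatic carbon para to a large group gives a 3.3-fold lower number from compound 3 to compound 4 (0.51 log units; beyond the scatter). The chloro of the 4-chlorophenyl group is therefore not required for inhibition in this pair, and plain phenyl gives the stronger inhibitor of the two. For the compounds shown here, this is the first pair that differs in one place, so it gives the first direct reading of a single change, and nothing measured here accounts for the size of the step.

Going by these compounds, whether any other group at this position, such as an amine, a nitrile or a carboxylic acid, would improve on hydrogen remains open. Also open, on these data alone, is whether the same change would carry over to compounds with a different group in place of the phenyl ring, such as the indole-bearing compound 1.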